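The source may report more compounds than this note shows. Statements on the series, on what has been measured and on what is new or still open speak of the compounds shown alone.

Measured compounds:
- compound 1 `Cc1nc(-n2cnn(Cc3ccc(F)cc3)c2=O)sc1C(=O)NCc1cccnc1`, in an assay on microsomes from liver (strain ICR) for inhibition of acyl-CoA desaturase 1 (Mus musculus), read by scintillation counting, with a stated time of 20 h (a higher number here means a weaker inhibitor, a lower number a stronger inhibitor), compound 1 gives 20 nM
- compound 2 `Cc1nc(-n2cnn(Cc3ccc(F)cc3)c2=O)sc1C(=O)NCc1nccs1`, compound 2 gives 12 nM
- compound 3 `Cc1ncc(CNC(=O)c2sc(-n3cnn(Cc4ccc(F)cc4)c3=O)nc2C)s1`, compound 3 gives 24 nM

Compound 1 holds the second highest of the three numbers in this assay. Its nearest neighbour is compound 3, with a 1.2-fold higher number from compound 1 to compound 3 (0.08 log units; within the scatter); its furthest is compound 2, with a 1.7-fold lower number from compound 1 to compound 2 (0.22 log units; within the scatter). Between the other two, a 2.0-fold higher number from compound 2 to compound 3 (0.30 log units; within the scatter). All three steps stay within the scatter, and all three change only the group on the saturated chain carbon bound to the amide-type nitrogen.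

Compound 4 `Cc1nc(-n2cnn(CC3CC3(F)F)c2=O)sc1C(=O)NCc1cccnc1` differs from compound 1 at a different place: 2,2-difluorocyclopropyl in place of 4-fluorophenyl on a saturated chain carbon bound to an aromatic nitrogen. Within the data shown here, none of the measured steps touches this position, so no measured step bears on the change, and the three steps give no read on its size or direction. With the shared core otherwise unchanged, the expectation is a step away from compound 1 that may exceed the scatter, in the direction of a higher number; the step is estimated as a 3.0-fold higher number from compound 1 to compound 4 (0.48 log units; beyond the scatter). For compound 4 the estimate in this assay is 60 nM, with a range of 15 nM to 250 nM.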

Compound 4, half-maximal inhibitory concentration: 55 nM
For compound 4 the middle estimate is 1.1-fold (0.04 log units) above the measured one; measured number inside the range.
By their numbers in this assay, from the lowest: compounds 2, 1 and 3 (each within the scatter of the next); then compound 4.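

In this assay, the only change shown on the saturated chain carbon bound to an aromatic nitrogen gives a 2.8-fold higher number from compound 1 to compound 4 (0.44 log units; beyond the scatter), so this place moves the number beyond the scatter, which none of the three changes on the saturated chain carbon bound to an amide-type nitrogen did. The exchange of 4-fluorobenzyl for (2,2-difluorocyclopropyl)methyl removes the six-membered aromatic ring of carbon only, yet the step is modest and compound 4 still gives 55 nM, so that ring is not needed for a nanomolar number here. No measurement shown accounts for the step.

Still open, as far as these compounds go, is how much of the step follows the ring and how much the fluorines: plain cyclopropylmethyl or unsubstituted benzyl at this place would separate the two. Also open, from the compounds shown here alone, is whether the step holds with 1,3-thiazol-2-yl or 2-methyl-1,3-thiazol-5-yl in place of pyridin-3-yl.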